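A Longer Side Chain on the Amino Acid Carbon

A few compounds are considered here, and "the series" means these few. Any claim that something is new, unique, unknown or untested is made for them only; others in the source may bear on it.

Compound 1 `O=C(CN(c1nc(Cl)nc2[nH]cnc12)C1CC1)NCC(=O)OCc1ccccc1` gives 41.9% in a functional assay on the whole organism (Tail, strain ICR) with Mus musculus as the target, in the tail flick test, with a stated time of 60 min, at a dose of 25 umol/kg by the oral route; on this read-out higher numbers stand for a stronger effect at the one dose given and lower numbers for a weaker effect.
Compound 2 `CC(C)[C@H](NC(=O)CN(c1nc(Cl)nc2[nH]cnc12)C1CC1)C(=O)OCc1ccccc1` gives 55.5% in this assay.
Compound 3 `CC[C@H](C)[C@H](NC(=O)CN(c1ncnc2c1ncn2C1CCCCO1)C1CC1)C(=O)OCc1ccccc1` gives 27.4% in this assay.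

Compound 3 stands lowest of the three numbers shown; compound 1 lies nearest to it and compound 2 furthest, both beyond the scatter. Compound 4 `CC(C)(C)OC(=O)NCCCC[C@H](NC(=O)CN(c1ncnc2c1ncn2C1CCCCO1)C1CC1)C(=O)OCc1ccccc1` differs from compound 3 in one place: 4-((tert-butoxycarbonyl)amino)butyl in place of sec-butyl on a saturated chain carbon bound to an amide-type nitrogen and a carbonyl carbon. Going by the values given here, the only measured step at that place is a number 13.6 percentage points higher from compound 1 to compound 2 (beyond the scatter), where a small group entered in place of hydrogen. Here a far larger group replaces another group, and no measured pair shows such a change, so that step is only a loose guide. The step of a number 2.6 percentage points higher from compound 3 to compound 4 (within the scatter) is therefore expected to be small. Compound 4 is estimated at 30% in this assay, with a range from 10% to 55%.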

Compound 4, a percentage reported as activity, at one dose (the size of the read-out at that dose, not a potency): 32.7%
Compound 4: the middle estimate sits 2.7 percentage points below what was measured, within the range that was stated.
By their numbers in this assay, from the lowest: compounds 3, 4 and 1 (each within the scatter of the next, the first and the last beyond it); then compound 2.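

Replacing sec-butyl with the much larger 4-((tert-butoxycarbonyl)amino)butyl on the saturated chain carbon gives a number 5.3 percentage points higher from compound 3 to compound 4 (within the scatter) in this assay. The earlier step at this place replaced only hydrogen with isopropyl, whereas this pair shows that a long chain carrying a carbamate-type group can enter without a change beyond the scatter. Nothing available explains this result.

The compounds shown leave open how a free amine or a carboxylic acid on the chain would read in this assay.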